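A few compounds are considered here, and "the series" means these few. Any claim that something is new, unique, unknown or untested is made for them only; others in the source may bear on it.

Three compounds built on one shared core were tested in a functional assay on Vero cells (Chlorocebus sabaeus) for cytotoxicity; on this read-out lower numbers stand for stronger inhibition and higher numbers for weaker inhibition. Compound 1 `O=c1[nH]c(=O)n(C2C[C@@H](O)[C@@H](CO)O2)nc1/C=C(\F)Br` gives only a limit in this assay, > 500 ug/mL. Compound 2 `O=c1[nH]c(=O)n(C2C[C@@H](O)[C@@H](CO)O2)nc1/C=C/Cl` likewise gives only a limit in this assay, > 500 ug/mL. Between these two the step that the two limits leave unreadable from compound 1 to compound 2 cannot be read. For the measured compounds named here, compound 3 `O=c1[nH]c(=O)n(C2C[C@@H](O)[C@@H](CO)O2)nc1-c1ccoc1` is the sole compound with an actual number: in this assay compound 3 gives 45 ug/mL. The steps onto compound 3 are both large, an at least 11-fold lower number from compound 1 to compound 3 (1.04 log units; beyond the scatter) and an at least 11-fold lower number from compound 2 to compound 3 (1.04 log units; beyond the scatter), each leading from a group without a ring to the furan-3-yl ring. Compound 4 `O=c1[nH]c(=O)n(C2C[C@@H](O)[C@@H](CO)O2)nc1CC(F)(F)F` has not yet been measured. It differs from compound 3 in one place: 2,2,2-trifluoroethyl in place of furan-3-yl on an aromatic carbon. The change removes the furan-3-yl ring and puts a group without a ring in its place, so the two measured steps bear on it in reverse, both pointing from a number back toward (the limit of > 500 ug/mL in this assay, at which 2 of the 3 values shown sit). A step of that kind, with a higher number, is therefore expected: a 6.7-fold higher number from compound 3 to compound 4 (0.82 log units; beyond the scatter). Compound 4 is expected to give roughly 300 ug/mL in this assay, in a range from 80 ug/mL to 600 ug/mL, with a fair chance that only a limit is reported.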

Compound 4, concentration for 50% inhibition: > 500 ug/mL
Compound 4: only a limit was reported (the forecaster's own chance of this, stated with the estimate: 55%); middle value at least 1.6-fold (0.22 log units) away from the limit.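

On the aromatic carbon next to the ring nitrogen, 2,2,2-trifluoroethyl in place of furan-3-yl gives an at least 11-fold higher number from compound 3 to compound 4 (1.04 log units; beyond the scatter) in this assay, so this step is as large as it can be read against the limit. The earlier compounds carried only halogenated ethenyl groups here, and this result extends the picture to a ring-free group with no carbon-carbon double bond, leaving furan-3-yl as the only group among these four that gives an actual number, with the steps among the other three compounds unreadable. All three ring-free groups end at the same place: the limit of > 500 ug/mL in this assay, at which 3 of the 4 values shown sit.

What the compounds shown leave open is whether the lower number belongs to the furan-3-yl ring in particular or to aromatic rings at this place more widely. A phenyl or thiophen-3-yl ring would bear on that, and an amine or a longer alkyl chain would test how far the ring-free groups share this limit.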